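Stripping the Bromo Group: What Compound 4 Might Give

The compounds below may be only part of what the source reports. "The series", "measured", "known", "first", "only" and "open" are said of these compounds alone.

Among the measured compounds shown here, compound 3 `O=c1c(-c2cccc(Br)c2)nc2ccccc2n1Cc1ccccc1` gives 330 nM in an assay on cells for activation of Cystic fibrosis transmembrane conductance regulator (Homo sapiens), read by fluorescence, with a stated time of 10 min (on this read-out higher numbers stand for an effect only at larger amounts of compound and lower numbers for an effect already at smaller amounts), the second highest of the three numbers measured so far. Its nearest neighbour is compound 2 `O=c1c(-c2ccc(C(F)(F)F)cc2)nc2ccccc2n1Cc1ccccc1`, which gives 1000 nM in this assay, and the furthest is compound 1 `O=c1c(-c2cccc([N+](=O)[O-])c2)nc2ccccc2n1Cc1ccccc1`, which gives 9 nM. For the measured compounds named here, the only measured step that reaches compound 3 is a 37-fold higher number from compound 1 to compound 3 (1.56 log units; beyond the scatter), a large movement in this assay. Compound 4 `O=c1c(-c2ccccc2)nc2ccccc2n1Cc1ccccc1` differs from compound 3 by hydrogen in place of bromo on an aromatic carbon, on an aromatic carbon of a six-membered aromatic ring of carbon only, meta to a large group. Going by the values given here, no measured pair removes a substituent from that ring outright, so the evidence bearing on this change is indirect: the swap from nitro to bromo was large, and the values of compound 2 and compound 3 show that two different groups on that ring sit well apart. The writer therefore expects a modest weakening for compound 4, a 2.4-fold higher number from compound 3 to compound 4 (0.38 log units; beyond the scatter), in this assay. Compound 4 is estimated at 800 nM, within a range of 250 nM to 2500 nM.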

Compound 4, half-maximal effective concentration: 5000 nM
Estimate against measurement, compound 4: 6.3-fold (0.80 log units) below, and the stated range ends below it.
By their numbers in this assay, from the lowest: compound 1; then compound 3; then compound 2; then compound 4.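

In this assay the unsubstituted ring turns out to be the weakest of the four, so none of the three groups is merely tolerated here: each, set against hydrogen, goes with a lower number. Hydrogen in place of bromo gives a 15-fold higher number from compound 3 to compound 4 (1.18 log units; beyond the scatter), hydrogen in place of trifluoromethyl gives a 5.0-fold higher number from compound 2 to compound 4 (0.70 log units; beyond the scatter), and hydrogen in place of nitro gives a 560-fold higher number from compound 1 to compound 4 (2.74 log units; beyond the scatter), so bromo keeps only part of the much larger gain seen with nitro. Nothing available here explains the gain that any of these groups brings.

The compounds shown leave open whether an amine, a carboxylic acid or a methoxy group on this ring would come closer to nitro or to hydrogen. From the compounds shown here alone, whether bromo or nitro would hold its effect on another carbon of the ring also stays open.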